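This account rests on a few compounds, and the source may have more. Where it says the series, first, only, none or still open, it means among the compounds named here.

Measured in a functional assay on FaDu cells (Homo sapiens) for inhibition, read by sulforhodamine B assay; a higher number here means a weaker inhibitor, a lower number a stronger inhibitor:
- compound 1 `COC(=O)CC/C(C)=C/Cc1c(OC)c(C)c2c(c1OCC#CCN1CCN(c3ccccc3F)CC1)C(=O)OC2`: > 50000 nM
- compound 2 `COC(=O)CC/C(C)=C/Cc1c(OC)c(C)c2c(c1OCC#CCN1CCN(C(c3ccccc3)c3ccc(Cl)cc3)CC1)C(=O)OC2`: > 50000 nM

Compound 1 gives only a limit, > 50000 nM, and no number. Compound 2 likewise gives only a limit, > 50000 nM. Among the compounds with values here, the series so far is therefore described by the limit of > 50000 nM in this assay, at which 2 of the 2 values shown sit, and no potency order can be read from it.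

The next compound to be tested in this assay is compound 3 `COC(=O)CC/C(C)=C/Cc1c(OC)c(C)c2c(c1OCC#CCN1CCN(c3ccccc3OC)CC1)C(=O)OC2`. Relative to compound 1, it has methoxy in place of fluoro on an aromatic carbon of a six-membered aromatic ring of carbon only, ortho to a large group, so 2-fluorophenyl becomes 2-methoxyphenyl: methoxy in place of fluoro on an aromatic carbon.

Within the data shown here, no measured pair shows the size of this change. The expectation rests on compound 1 at > 50000 nM, which is a limit. Little movement is expected, and another limit in place of a number is the likeliest expected outcome: a number no higher from compound 1 to compound 3 (the limit leaves the size open). For compound 3 the estimate is 50000 nM, with an expected range of 25000 nM to 100000 nM.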

Compound 3, half-maximal inhibitory concentration: > 50000 nM
Compound 3: no number, only a limit; the forecaster's own chance of this, stated with the estimate: 75%; the middle value sits exactly at the limit.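

Compound 3, like compound 1, gives only a limit and no number, so the change from 2-fluorophenyl to 2-methoxyphenyl yields no readable step. The series stays at a single limit: the limit of > 50000 nM in this assay, at which 3 of the 3 values shown sit.

The compounds shown leave open whether any change on the shared core gives a measurable number in this assay.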